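Moving the chlorines in a series at the assay limit

The compounds below may be only part of what the source reports. "The series", "measured", "known", "first", "only" and "open" are said of these compounds alone.

In an ADME assay on NHDF cells (Homo sapiens) for cytotoxicity, read by MTT assay, with a stated time of 72 h (a higher number here means a weaker inhibitor, a lower number a stronger inhibitor), compound 1 (`COc1cccc(/C=C2\CCC/C(=C\c3ccccc3Br)C2=O)c1OC`) reads > 50000 nM as a limit of the assay, not a number. Compound 2 (`COc1cccc(/C=C2\CCC/C(=C\c3cccc(Cl)c3Cl)C2=O)c1OC`) reads > 50000 nM and is likewise known only as a limit. Within the data shown here, the series so far comes down to the limit of > 50000 nM in this assay, at which 2 of the 2 values shown sit, and nothing more.

Compound 3 (`COc1cccc(/C=C2\CCC/C(=C\c3ccc(Cl)c(Cl)c3)C2=O)c1OC`) has the same atoms as compound 2, joined differently (3,4-dichlorophenyl in place of 2,3-dichlorophenyl on a double-bonded chain carbon bound to a double-bonded ring carbon): 3,4-dichlorophenyl in place of 2,3-dichlorophenyl on a double-bonded chain carbon bound to a double-bonded ring carbon.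

Among the measured compounds shown here, the one measured step at this place (a step that the two limits leave unreadable from compound 1 to compound 2) has no readable size, so it offers no size to carry over. In this assay the expected a number no higher from compound 2 to compound 3 (the limit leaves the size open) stays within the usual scatter, with no direction favoured. Compound 3 is estimated at 50000 nM (range 20000 nM to 80000 nM) and will most likely be reported as a limit again.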

Compound 3, half-maximal inhibitory concentration: 25500 nM
The estimate for compound 3 lay 2.0-fold (0.29 log units) above the measured number; the measured number falls inside the stated range.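

In this assay, among these compounds, compound 3 is the first to read as a number rather than a limit, so this place on a double-bonded chain carbon bound to a double-bonded ring carbon now has steps with a readable floor. The change to 3,4-dichlorophenyl shows an at least 1.9-fold lower number from compound 2 to compound 3 (0.29 log units; that floor lies within the scatter), and the same group in place of 2-bromophenyl shows an at least 1.9-fold lower number from compound 1 to compound 3 (0.29 log units; that floor lies within the scatter). Both floors stay within the scatter, so neither change is established as a real shift, and the remaining values give no further reading: the limit of > 50000 nM in this assay, at which 2 of the 3 values shown sit.

As far as these compounds go, the true size of both steps stays open, and the step between the two limit compounds cannot be read. Also open, from the compounds shown here alone, is how the series reads with an amine or a carboxylic acid on this ring in place of the halogens.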